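Swapping Trifluoromethyl for Bromo on a Sulfonamide Benzylamine

This account rests on a few compounds, and the source may have more. Where it says the series, first, only, none or still open, it means among the compounds named here.

Compound 1 `O=S(=O)(NCCCNCc1ccc(C(F)(F)F)cc1)c1cc(C(F)(F)F)cc(C(F)(F)F)c1` is one of two measured compounds. In a functional assay on MIA PaCa-2 cells (Homo sapiens) for inhibition, read by MTT assay, with a stated time of 72 h (on this read-out higher numbers stand for weaker inhibition of growth and lower numbers for stronger inhibition of growth), compound 1 gives 2500 nM, the lowest of the two numbers shown, while compound 2 `O=S(=O)(NCCCCCCNCc1ccc(Br)cc1)c1cc(C(F)(F)F)cc(C(F)(F)F)c1` gives 2970 nM; the two values lie within the usual scatter of each other. Compound 3 `O=S(=O)(NCCCNCc1ccc(Br)cc1)c1cc(C(F)(F)F)cc(C(F)(F)F)c1` differs from compound 1 by a single change: bromo in place of trifluoromethyl on an aromatic carbon. Among the compounds with values here, no measured pair shows this change alone, so its size is unknown. Compound 2 already carries bromo and gives 2970 nM. The step of a 1.1-fold higher number from compound 1 to compound 3 (0.03 log units; within the scatter) is therefore expected to be small, none beyond the scatter. Compound 3 is estimated at 2700 nM, within 1300 nM to 5500 nM.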

Compound 3, concentration for 50% growth inhibition: 2300 nM
Compound 3: middle estimate off by 1.2-fold (0.07 log units), on the high side, within the range that was stated.
By their numbers in this assay, from the lowest: compounds 3, 1 and 2 (each within the scatter of the next).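

Read directly for the first time, the change from 4-(trifluoromethyl)benzyl to 4-bromobenzyl gives in this assay a 1.1-fold lower number from compound 1 to compound 3 (0.04 log units; within the scatter) and so leaves the growth read-out unmoved at this position. Here a single bromine atom stands in for the four heavy atoms of trifluoromethyl with no step beyond the scatter. No available data explain this match.

Still open, on these data alone, is whether a carboxylic acid or a nitrile at this same position would move the number beyond the scatter.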